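The source may report more compounds than this note shows. Statements on the series, on what has been measured and on what is new or still open speak of the compounds shown alone.

Compound 3 `CN(C)c1ccc(C(=O)N2CCC(n3cncc3-c3ccc(OS(=O)(=O)c4cccc(C#N)c4)cc3)CC2)cc1` is the anchor of this account. In an assay on THP-1 cells for antagonist activity at P2X purinoceptor 7 (Homo sapiens), read by ELISA, with a stated time of 30 min (on this read-out lower numbers stand for stronger inhibition and higher numbers for weaker inhibition), compound 3 gives 10 nM, the lowest of the three numbers recorded; its nearest neighbour is compound 2 `N#Cc1cccc(S(=O)(=O)Oc2ccc(-c3cncn3C3CCN(C(=O)c4ccc([N+](=O)[O-])cc4)CC3)cc2)c1`, which in this assay gives 13 nM, and the step of a 1.3-fold lower number from compound 2 to compound 3 (0.11 log units; within the scatter) stays within the scatter. Compound 1 `O=C(NC1CC1)c1cccc(S(=O)(=O)Oc2ccc(-c3cncn3C3CCN(C(=O)c4ccc(Cl)c(C(F)(F)F)c4)CC3)cc2)c1` is furthest away and gives 58 nM in this assay, a gap that lies beyond the scatter.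

Compound 4 `CN(C)c1ccc(C(=O)N2CCC(n3cncc3-c3ccc(OS(=O)(=O)c4cccc(C(=O)NC5CC5)c4)cc3)CC2)cc1` is not yet measured. It differs from compound 3 in one place, (cyclopropylcarbamoyl in place of cyano on an aromatic carbon). For the measured compounds named here, no measured pair isolates this change. Going by the values given here, the one step recorded, from compound 2 to compound 3, concerns a different part of the molecule and so says nothing direct about it. Compound 1 does carry the cyclopropylcarbamoyl group and compound 2 the cyano group, but the two also differ in the acyl group on the piperidine, so their values can only be read together as a hint that the amide-bearing analogue may sit at a higher number. On that slender basis compound 4 is expected to give a step of a 2.5-fold higher number from compound 3 to compound 4 (0.40 log units; beyond the scatter), a modest move toward a higher number, with wide uncertainty. The estimate for compound 4 is 25 nM, with a range from 8 nM to 80 nM.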

Compound 4, half-maximal inhibitory concentration: 1.03 nM
The estimate for compound 4 lay 24-fold (1.39 log units) above the measured number, outside the stated range (below it).
By their numbers in this assay, from the lowest: compound 4; then compounds 3 and 2 (each within the scatter of the next); then compound 1.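

In this assay, for the compounds shown here, cyclopropylcarbamoyl in place of cyano, on an aromatic carbon meta to a large group, gives a 9.7-fold lower number from compound 3 to compound 4 (0.99 log units; beyond the scatter), so this is the first direct reading of the change, and it shows that the larger group is accepted at this position and goes with a clearly lower number. With cyclopropylcarbamoyl held constant, 4-(dimethylamino)phenyl in place of 4-chloro-3-(trifluoromethyl)phenyl on the carbonyl carbon gives a 56-fold lower number from compound 1 to compound 4 (1.75 log units; beyond the scatter), showing that the group at that other site also moves the number well beyond the scatter. No available evidence accounts for either step.

A methylcarbamoyl group or a carboxylic acid at this position would help separate the part played by the three-membered ring from that of the carbamoyl unit, including its amide hydrogen. From the compounds shown here alone, it also remains open whether cyclopropylcarbamoyl in place of cyano gives a step of similar size when a group other than 4-(dimethylamino)phenyl sits on the carbonyl carbon.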